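Swapping Cyano for Phenyl: Expected Metabolic Stability

The compounds below may be only part of what the source reports. "The series", "measured", "known", "first", "only" and "open" are said of these compounds alone.

Among the compounds with values here, compound 1 `CCCNC(=O)C1CCN(C(=O)c2cc3sc(C#N)cc3n2Cc2ccc(OC)cc2)CC1` is the only compound here with a single number in an ADME assay on microsomes from liver (Homo sapiens) for metabolic stability (a higher number here means that the compound lasts longer, a lower number that the compound disappears faster), where compound 1 gives 0.187 h. Compound 2 `CCCNC(=O)C1CCN(C(=O)c2cc3sc(Br)cc3n2Cc2ccc(OC)cc2)CC1` was run more than once in this assay, and compound 2 gives 0.0485 h; 0.0588 h (2 entries). Compound 3 `CCCNC(=O)C1CCN(C(=O)c2cc3sc(-c4ccccc4)cc3n2Cc2ccc(OC)cc2)CC1` is not yet measured. It differs from compound 1 by phenyl in place of cyano on an aromatic carbon. Within the data shown here, no measured pair shows this exact change, so its direction is open; a modest shortening of half-life is expected, though a result within scatter would not surprise. For compound 3 in this assay the half-life is estimated at 0.11 h, between 0.04 h and 0.3 h. That estimate corresponds to an expected step of a 1.7-fold lower number from compound 1 to compound 3 (0.23 log units; within the scatter).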

Compound 3, half-life: 0.737 h
For compound 3 the middle estimate is 6.7-fold (0.83 log units) below the measured one; measured number above the stated range.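

Replacing cyano with phenyl on this aromatic carbon, next to the ring sulfur, gives a 3.9-fold higher number from compound 1 to compound 3 (0.60 log units; beyond the scatter) in this assay. This first measured step at the position shows that a larger group carrying a six-membered aromatic ring can sit here while the compound lasts longer. Repeat measurements at this position lie close together, so a step of this size stands out from the noise: the several entries of compound 2 in this assay, 0.0485 h; 0.0588 h (2 entries)

Which feature of the phenyl ring matters remains open. So does whether a pyridine ring or an amine here would also lengthen the half-life.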